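A Methoxy Change Made Twice in One Lipophilicity Series

The source may report more compounds than this note shows. Statements on the series, on what has been measured and on what is new or still open speak of the compounds shown alone.

Measured so far in a physicochemical assay for lipophilicity; a lower number here means a more polar compound, a higher number a more lipophilic compound:
Compound 1 `COc1c(OC)c(OC(C)=O)c2ccccc2c1OC(C)=O` gives 2.39.
Compound 2 `CCC(=O)Oc1c(OC)c(OC)c(OC(=O)CC)c2ccccc12` gives 3.44.
Compound 3 `COc1c(OC)c(OC(C)=O)c2c(OC)cccc2c1OC(C)=O` gives 2.43.

Compound 3 differs from compound 1 by methoxy in place of hydrogen on an aromatic carbon. In this assay that step was a number 0.04 log units higher from compound 1 to compound 3 (within the scatter). Compound 2 stands well above both compound 1 and compound 3; how the core of compound 2 differs from the core of compound 1 is not broken down here.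

Compound 4 `CCC(=O)Oc1c(OC)c(OC)c(OC(=O)CC)c2c(OC)cccc12` differs from compound 2 by methoxy in place of hydrogen on an aromatic carbon, the same change at the same kind of place as that from compound 1 to compound 3. The expected step in this assay is a number 0.05 log units higher from compound 2 to compound 4 (within the scatter), resting on the measured step of a number 0.04 log units higher from compound 1 to compound 3 (within the scatter). For compound 4 the estimate in this assay is therefore 3.49, expected to lie between 3.2 and 3.8.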

Compound 4, partition coefficient: 3.44
Beside the measured number, compound 4's estimate is 0.05 log units above it, and the stated range covers the measured number.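

In this assay, methoxy in place of hydrogen on an aromatic carbon gives no change at the digits printed from compound 2 to compound 4 (within the scatter), and on the other core the same change gives a number 0.04 log units higher from compound 1 to compound 3 (within the scatter). The change therefore carries across these two cores with a step inside the scatter each time, but two pairs do not show that it would behave the same way on any further core or at another place on the ring. Nothing available here accounts for this result.

The compounds shown leave open what an amine, a carboxylic acid or a longer chain in place of that hydrogen would do to the partition coefficient. They also leave open whether any such group would carry from one core to the other as methoxy does.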